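Swapping Bromo for Methoxy on the Aryl Ring

The source may hold more compounds than are shown below. What is called first, only, known or untested is meant among the compounds shown, and "the series" means these compounds.

Of the compounds shown here, two have so far been tested in a toxicity assay on the whole organism (strain Icem-CET (SPF Caw)) for cytotoxicity, with Mus musculus as the target; a lower number here means that less compound is needed, a higher number that more compound is needed for the effect. Compound 1 `C#CCNC(=O)/C(C)=C(\C)c1cc(OC)c(OC)c(OC)c1` gives 300 mg/kg in this assay, and compound 2 `C/C(C(=O)NC1CC1)=C(/C)c1ccc(Br)cc1` gives 600 mg/kg. Of the two numbers, compound 2 holds the higher, yet its gap to compound 1 lies within the scatter, so the pair cannot be told apart. Compound 3 `COc1ccc(/C(C)=C(\C)C(=O)NC2CC2)cc1` differs from compound 2 in one place: methoxy in place of bromo on an aromatic carbon. Going by the values given here, no measured step of this kind exists among the tested compounds; the step is expected to be small, a 1.2-fold lower number from compound 2 to compound 3 (0.08 log units; within the scatter), and not beyond the scatter. Compound 3 is estimated at 500 mg/kg, with a range from 250 mg/kg to 1000 mg/kg.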

Compound 3, dose for half-maximal effect: 300 mg/kg
The estimate for compound 3 lay 1.7-fold (0.22 log units) above the measured number; the range from low to high includes it.
By their numbers in this assay, from the lowest: compounds 1, 3 and 2 (each within the scatter of the next).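

The only one-place change shown at this position, methoxy in place of bromo on an aromatic carbon para to a large group, gives a 2.0-fold lower number from compound 2 to compound 3 (0.30 log units; within the scatter) in this assay and so leaves compound 2 and compound 3 indistinguishable. Trading bromo for a group with one hydrogen-bond acceptor therefore produces no readable change here. No evidence is available that bears on this result. On these data alone, whether a different group at this place, such as an amine or a carboxylic acid, would shift the number beyond the scatter remains open.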